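The compounds below may be only part of what the source reports. "The series", "measured", "known", "first", "only" and "open" are said of these compounds alone.

Compound 2 `COc1ccc(Cn2c(-c3ccccc3)c(-c3ccccc3)c3c(=N)n(CCCO)cnc32)cc1` gives in an ADME assay on microsomes from liver (Mus musculus, strain CD1) for metabolic stability, read by LC-MS, using NADPH, with a stated time of 60 min (on this read-out higher numbers stand for a longer-lived compound and lower numbers for a shorter-lived compound), a half-life of 0.332 h. Within the data shown here, compound 1 `COc1ccc(Cn2c(-c3ccccc3)c(-c3ccccc3)c3c(=N)n(CC4CCOCC4)cnc32)cc1`, the only other compound measured in this assay, gives 0.217 h, so compound 2 stands within the scatter of its single neighbour. Among the measured compounds shown here, the one step in hand, a 1.5-fold higher number from compound 1 to compound 2 (0.18 log units; within the scatter), altered the chain on the aromatic nitrogen without leaving the scatter. Compound 3 `COc1ccc(Cn2c(-c3ccccc3)c(-c3ccccc3)c3c(=N)n(CCO)cnc32)cc1` differs from compound 2 by hydroxy in place of hydroxymethyl on a saturated chain carbon, two bonds along the chain from an aromatic nitrogen, again a change of the same chain. On that single step, no movement beyond the scatter is expected, with a 1.1-fold lower number from compound 2 to compound 3 (0.04 log units; within the scatter) in this assay. Compound 3 is therefore estimated at 0.3 h, within 0.12 h to 0.75 h.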

Compound 3, half-life: 0.518 h
For compound 3 the middle estimate is 1.7-fold (0.24 log units) below the measured one; low and high end bracket the measured number.
By their numbers in this assay, from the lowest: compounds 1, 2 and 3 (each within the scatter of the next, the first and the last beyond it).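

With hydroxy in place of hydroxymethyl, two bonds along the chain from an aromatic nitrogen, the chain gives a 1.6-fold higher number from compound 2 to compound 3 (0.19 log units; within the scatter). Hydroxymethyl in place of oxan-4-yl on the saturated chain carbon bound to that nitrogen gives a 2.4-fold higher number from compound 1 to compound 3 (0.38 log units; beyond the scatter), the first step on this chain to pass the scatter in this assay. No measurement here offers a reason for either step. The compounds shown leave open how an amine or a carboxylic acid in place of the hydroxy would read in this assay. They also leave open whether a methoxy group would match it.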